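Trading a Hydroxy Chain End for Trifluoromethyl

The compounds below may be only part of what the source reports. "The series", "measured", "known", "first", "only" and "open" are said of these compounds alone.

Compound 2 `CS(=O)(=O)c1nn(Cc2nc3cc(Cl)ccc3n2CCCCO)c2cnccc12` has been measured in a physicochemical assay for solubility, read by spectrophotometry, in phosphate buffer, at pH 6.5 (on this read-out higher numbers stand for higher solubility and lower numbers for lower solubility), where compound 2 gives 147 ug/mL. That is the higher of the two numbers available; compound 1 `CN(C)S(=O)(=O)c1cn(Cc2nc3cc(Cl)ccc3n2CCCS(C)(=O)=O)c2ccccc12`, built on a different core, gives 3 ug/mL in this assay, and the gap between the two lies far beyond the usual scatter. Compound 3 `CS(=O)(=O)c1nn(Cc2nc3cc(Cl)ccc3n2CCCCC(F)(F)F)c2cnccc12` has not yet been measured. It differs from compound 2 in a single place: trifluoromethyl in place of hydroxy on a saturated chain carbon, four bonds along the chain from an aromatic nitrogen. The group that leaves counts one hydrogen-bond donor and one hydrogen-bond acceptor; the group that enters counts none. Among the measured compounds shown here, no measured pair shows what such a swap does here, so the expectation rests on compound 2 alone. A drop in solubility is expected, with an estimated step of a 9.8-fold lower number from compound 2 to compound 3 (0.99 log units; beyond the scatter). Compound 3 is therefore estimated at 15 ug/mL, in a range from 4 ug/mL to 60 ug/mL.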

Compound 3, solubility: 1 ug/mL
The estimate for compound 3 lay 15-fold (1.18 log units) above the measured number, outside the stated range (below it).
By their numbers in this assay, from the lowest: compound 3; then compound 1; then compound 2.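

In this assay trifluoromethyl in place of hydroxy at the chain end gives a 150-fold lower number from compound 2 to compound 3 (2.17 log units; beyond the scatter) on a large scale, so this is a place where the read-out responds strongly. Among the compounds shown here, this is the first pair that differs in one place only, and it shows that a change at the end of the chain, with the shared core left untouched, is enough on its own to move the number this far. Nothing measured here tells what lies behind the step.

In this pair the hydrogen-bond donor and acceptor leave while the heavy atoms of trifluoromethyl enter, so the compounds shown cannot separate these changes. Also open, from the compounds shown here alone, is where a chain ending in an amine, a carboxylic acid or a plain methyl would fall relative to compound 2 and compound 3.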